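From 4-bromobenzyl to 4-nitrobenzyl

The compounds below may be only part of what the source reports. "The series", "measured", "known", "first", "only" and "open" are said of these compounds alone.

In a functional assay on Bel-7402 cells (Homo sapiens) for antiproliferative activity, read by MTT assay, with a stated time of 72 h (on this read-out lower numbers stand for stronger inhibition and higher numbers for weaker inhibition), compound 1 `C=C1C(=O)O[C@H]2[C@H]1CC/C(COC(=O)Cn1cc(F)c(=O)n(Cc3ccccc3)c1=O)=C\CC[C@@]1(C)O[C@@H]21` gives 3980 nM and compound 2 `C=C1C(=O)O[C@H]2[C@H]1CC/C(COC(=O)Cn1cc(F)c(=O)n(Cc3ccc(Br)cc3)c1=O)=C\CC[C@@]1(C)O[C@@H]21` gives 2670 nM which places compound 2 within the scatter of compound 1. Compound 3 `C=C1C(=O)O[C@H]2[C@H]1CC/C(COC(=O)Cn1cc(F)c(=O)n(Cc3ccc([N+](=O)[O-])cc3)c1=O)=C\CC[C@@]1(C)O[C@@H]21` has not been measured yet and differs from compound 2 by nitro in place of bromo on an aromatic carbon. Among the measured compounds shown here, the one measured step at this place swaps hydrogen for bromo (a 1.5-fold lower number from compound 1 to compound 2 (0.17 log units; within the scatter)) and so offers no sign of a large move. Any change here is therefore expected to stay within the scatter (a 1.0-fold higher number from compound 2 to compound 3 (0.02 log units; within the scatter)). In this assay the expected value for compound 3 is 2800 nM and the range runs from 1100 nM up to 7000 nM for this estimate.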

Compound 3, half-maximal inhibitory concentration: 4070 nM
Beside the measured number, compound 3's estimate is 1.5-fold (0.16 log units) below it; low and high end bracket the measured number.
By their numbers in this assay, from the lowest: compounds 2, 1 and 3 (each within the scatter of the next).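

In this assay, a nitro group at this spot on the benzyl ring gives the same picture as bromo: the swap from bromo reads (a 1.5-fold higher number from compound 2 to compound 3 (0.18 log units; within the scatter)), and nitro in place of hydrogen reads (a 1.0-fold higher number from compound 1 to compound 3 (0.01 log units; within the scatter)). So two different groups, one of a single heavy atom and one of three, now leave the number within the scatter of the plain benzyl compound. Nothing available accounts for this flat result.

Still open, as far as these compounds go, is whether an amine or a carboxylic acid at this spot, or a longer chain in place of the benzyl group, would move the number beyond the scatter.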